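Methoxy Added to the Aryl Ring of Two Thiosemicarbazones

The source may hold more compounds than are shown below. What is called first, only, known or untested is meant among the compounds shown, and "the series" means these compounds.

Measured so far:
compound 1 `CC1=CC[C@H](C(C)(C)NC(=S)N/N=C/c2ccc(O)cc2)CC1` — in a functional assay on K562 cells (Homo sapiens) for inhibition, read by sulforhodamine B assay, with a stated time of 48 h (a lower number here means a stronger inhibitor of growth, a higher number a weaker inhibitor of growth), compound 1 gives only a limit, > 100000 nM
compound 2 `COc1cc(/C=N/NC(=S)NC(C)(C)[C@H]2CC=C(C)CC2)ccc1O` — in this assay compound 2 gives 85200 nM
compound 3 `CC1=CC[C@H](C(C)(C)NC(=S)N/N=C(\C)c2ccccc2)CC1` — in this assay compound 3 gives only a limit, > 100000 nM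

The change methoxy in place of hydrogen on an aromatic carbon produced an at least 1.1-fold lower number from compound 1 to compound 2 (0.06 log units; that floor lies within the scatter); that reading is bounded by the limit of > 100000 nM in this assay, at which 2 of the 3 values shown sit. The difference between the core of compound 1 and the core of compound 3 is not broken down here. Compound 4 `COc1ccc(/C(C)=N/NC(=S)NC(C)(C)[C@H]2CC=C(C)CC2)cc1` carries the same kind of change as compound 2, (methoxy in place of hydrogen on an aromatic carbon), but around a different place: in compound 2 the methoxy sits ortho to a hydroxy group and meta to a large group, in compound 4 para to a large group. The step from compound 3 to compound 4 is expected to be a number no higher from compound 3 to compound 4 (the limit leaves the size open), resting on an at least 1.1-fold lower number from compound 1 to compound 2 (0.06 log units; that floor lies within the scatter) and on the limit of compound 3. Compound 4 is therefore estimated at 100000 nM, between 50000 nM and 200000 nM.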

Compound 4, concentration for total growth inhibition: > 100000 nM
Compound 4: a limit, no number; the forecaster's own chance of this, stated with the estimate: 60%; the middle value lies on the limit itself.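

In this assay compound 4 gives only a limit, > 100000 nM. No step from compound 3 to compound 4 can be read, because both values are limits: the limit of > 100000 nM in this assay, at which 3 of the 4 values shown sit.

As far as these compounds go, whether phenyl to 4-methoxyphenyl changes growth inhibition at all remains open.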